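The source may report more compounds than this note shows. Statements on the series, on what has been measured and on what is new or still open speak of the compounds shown alone.

The three measured compounds share one core and differ only in the group on the ring nitrogen: compound 1 `C#CCSc1nc(NCCC(C)C)c2ccncc2n1` carries isopentyl, compound 2 `C#CCSc1nc(Nc2ccccc2Cl)c2ccncc2n1` 2-chlorophenyl and compound 3 `C#CCSc1nc(Nc2ccc(Br)cc2)c2ccncc2n1` 4-bromophenyl. In a functional assay on PC-3 cells (Homo sapiens) for inhibition, read by MTT assay, with a stated time of 72 h (on this read-out lower numbers stand for stronger inhibition and higher numbers for weaker inhibition), compound 1 gives only a limit, > 80000 nM. Compound 2 also gives only a limit in this assay, > 80000 nM. Compound 3 gives 26000 nM in this assay, so that an at least 3.0-fold lower number from compound 2 to compound 3 (0.48 log units; beyond the scatter), while a step that the two limits leave unreadable from compound 1 to compound 2 and an at least 3.0-fold lower number from compound 1 to compound 3 (0.48 log units; beyond the scatter). Compound 2 therefore stands at the limit of > 80000 nM in this assay, at which 2 of the 3 values shown sit. Compound 4 `C#CCSc1nc(Nc2ccc(Cl)cc2Cl)c2ccncc2n1` differs from compound 2 by chloro in place of hydrogen on an aromatic carbon. Among the compounds with values here, only the step from compound 2 to compound 3 bears on this change, and it was at least modest. The expected step is an at least 2.2-fold lower number from compound 2 to compound 4 (0.35 log units; beyond the scatter), a lower number. Compound 4 is estimated at 35000 nM, from 12000 nM to 90000 nM.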

Compound 4, half-maximal inhibitory concentration: 30400 nM
Compound 4: the middle estimate sits 1.2-fold (0.06 log units) above what was measured, within the range that was stated.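

In this assay the added chloro gives an at least 2.6-fold lower number from compound 2 to compound 4 (0.42 log units; beyond the scatter), so one substitution on an aromatic carbon para to a large group and meta to a chloro group is enough to reach a readable value. The earlier step to compound 3 replaced the whole group on the nitrogen, whereas this change retains the chloro group of compound 2 and alters one place on its ring. Compound 2 gives only a limit, so this step has no readable upper size: the limit of > 80000 nM in this assay, at which 2 of the 4 values shown sit.

The compounds shown leave open whether a fluoro group, a methoxy group or an amine on that carbon would give a similar step. They also leave open whether chloro there would have the same effect without the other chloro group.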